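The compounds below may be only part of what the source reports. "The series", "measured", "known", "first", "only" and "open" are said of these compounds alone.

Of the compounds shown here, three have so far been tested in a functional assay on MCF7 cells (Homo sapiens) for cytotoxicity, read by sulforhodamine B assay, with a stated time of 48 h, tested at 0.01 uM; on this read-out higher numbers stand for a weaker effect at the one concentration tested and lower numbers for a stronger effect. Compound 3 `COc1ccc(-c2cc(/C=C/C(=O)c3ccc(N)cc3)[nH]n2)cc1OC` gives 89%. Compound 1 `COc1cc(-c2cc(/C=C/C(=O)c3ccc(N)cc3)[nH]n2)cc(OC)c1OC` gives 89%, and compound 2 `COc1ccc(C(=O)/C=C/c2cc(-c3cc(OC)c(OC)c(OC)c3)n[nH]2)cc1OC` gives 89%. Between compound 3 and compound 1 the structural change is methoxy in place of hydrogen on an aromatic carbon, and it made the step of no change at the digits printed from compound 3 to compound 1 (within the scatter). The step of no change at the digits printed from compound 1 to compound 2 (within the scatter) goes with a 3,4-dimethoxyphenyl in place of a 4-aminophenyl on the carbonyl carbon. The difference between the cores of compound 2 and compound 3 is not broken down here.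

Compound 4 `COc1cc(C(=O)/C=C/c2cc(-c3cc(OC)c(OC)c(OC)c3)n[nH]2)cc(OC)c1OC` has not yet been measured in this assay. It differs from compound 2 by methoxy in place of hydrogen on an aromatic carbon, the same change, in the same surroundings, as from compound 3 to compound 1. Because the step of no change at the digits printed from compound 3 to compound 1 (within the scatter) stayed within the scatter, the step of no change at the digits printed from compound 2 to compound 4 (within the scatter) is expected to be just as small. Compound 4 is therefore estimated at 89% in this assay, most likely between 79% and 97%.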

Compound 4, a percentage reported as activity, at one concentration (the size of the read-out at that concentration, not a potency): 95%
Beside the measured number, compound 4's estimate is 6 percentage points below it; the measured number falls inside the stated range.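

In this assay, methoxy in place of hydrogen on an aromatic carbon gives a number 6 percentage points higher from compound 2 to compound 4 (within the scatter). Set beside the earlier case, the change behaves alike on both cores, as far as these numbers can tell: the same change on two cores in this assay, no change at the digits printed (within the scatter) from compound 3 to compound 1 and a number 6 percentage points higher (within the scatter) from compound 2 to compound 4, 6 percentage points apart, within the scatter of two such steps This does not show that the methoxy has no effect in general or that the same would hold on a third core, since there are only two cores, each read at a single concentration, and a real difference smaller than the scatter would go unseen.

The compounds shown leave open what other groups would do at this place on the ring. A hydroxyl, a fluorine or a longer chain such as ethoxy could be compared with methoxy there.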